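Swapping a Small Sulfonyl Group for a Larger Aromatic One

The source may report more compounds than this note shows. Statements on the series, on what has been measured and on what is new or still open speak of the compounds shown alone.

Three compounds share one core and differ only in the group attached to the ring nitrogen. In a functional assay on HEK293 cells for agonist activity at nuclear receptor subfamily 1 group D member 1 (Homo sapiens), read by a luciferase reporter, with a stated time of 24 h (a lower number here means that less compound is needed, a higher number that more compound is needed for the effect), compound 1 `O=C(Oc1ccccc1)N1CCC(CN(Cc2ccc(Cl)cc2)Cc2ccc([N+](=O)[O-])s2)C1` gives "not determined" (no result reported). Compound 2 `CCCCNC(=O)N1CCC(CN(Cc2ccc(Cl)cc2)Cc2ccc([N+](=O)[O-])s2)C1` carries a butylcarbamoyl group, and in this assay compound 2 gives 670 nM. Compound 3 `CS(=O)(=O)N1CCC(CN(Cc2ccc(Cl)cc2)Cc2ccc([N+](=O)[O-])s2)C1` carries a methylsulfonyl group, and in this assay compound 3 gives 570 nM. Of the two numbers recorded, the value of compound 3 is the lower, yet the step of a 1.2-fold lower number from compound 2 to compound 3 (0.07 log units; within the scatter) lies within the scatter, so the two compounds cannot be ranked against each other.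

Compound 4 `O=[N+]([O-])c1ccc(CN(Cc2ccc(Cl)cc2)CC2CCN(S(=O)(=O)c3cccc4ccccc34)C2)s1` is the next step: naphthalen-1-yl in place of methyl on a sulfonyl sulfur. Going by the values given here, no measured step bears directly on this change. Among the compounds with values here, the only step available, a 1.2-fold lower number from compound 2 to compound 3 (0.07 log units; within the scatter), exchanged one small group for another and barely moved the number, which gives no guidance on what a large aromatic group on the sulfonyl sulfur will do. The expectation therefore stays close to compound 3, with a wide range in both directions. Compound 4 is expected to give about 400 nM, within a range from 90 nM to 1800 nM. This estimate corresponds to a step of a 1.4-fold lower number from compound 3 to compound 4 (0.15 log units; within the scatter), which is expected to stay within the scatter.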

Compound 4, half-maximal effective concentration: 450 nM
Estimate against measurement, compound 4: 1.1-fold (0.05 log units) below, and the stated range covers the measured number.
By their numbers in this assay, from the lowest: compounds 4, 3 and 2 (each within the scatter of the next).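

Exchanging methyl (1 heavy atom) for naphthalen-1-yl (10 heavy atoms, in 2 six-membered aromatic rings) on a sulfonyl sulfur gives, in this assay, a 1.3-fold lower number from compound 3 to compound 4 (0.10 log units; within the scatter). The earlier pair showed only that butylcarbamoyl and methylsulfonyl on the ring nitrogen could not be told apart; this pair keeps the sulfonyl group and changes only what it carries, and shows that a much larger group on that sulfur still leaves the number within the scatter. No measurement shown here explains why the number holds across so large an exchange.

Going by these compounds alone, only two groups on the sulfonyl sulfur can be compared, so this is one observation and not a rule for the position, and it remains open whether a single phenyl ring or a longer alkyl chain there would fit the same picture. Going by these compounds, it is equally open whether a naphthalen-1-yl group carrying an amine or a carboxylic acid would keep the number within the scatter of compound 4.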